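Shared core with a varied substituent: acid dissociation notes

The source may report more compounds than this note shows. Statements on the series, on what has been measured and on what is new or still open speak of the compounds shown alone.

Of the compounds shown here, three have been measured. Compound 1 `COc1ccc(F)cc1CNCCCNc1ccnc2cc(Oc3ccc(F)cc3)ccc12` gives 9.28 in a physicochemical assay for acid dissociation. Compound 2 `COc1ccc(F)cc1CNCCCNc1ccnc2cc(Oc3cccc(N(C)C)c3)ccc12` gives 9.28, and compound 3 `COc1ccc(F)cc1CNCCCNc1ccnc2cc(Cc3ccccc3)ccc12` gives 9.47. The three numbers lie within the usual scatter of one another: no change at the digits printed from compound 1 to compound 2 (within the scatter), a number 0.19 log units higher from compound 1 to compound 3 (within the scatter) and a number 0.19 log units higher from compound 2 to compound 3 (within the scatter). Compound 3 carries the largest number of the three, but its distance to compound 1 and to compound 2 is of the size that repeated measurements of this kind show anyway, so no ranking of the three can be read from these numbers.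

Compound 4 `COc1ccc(F)cc1CNCCCNc1ccnc2cc(CC(C)C)ccc12` has not been measured. It differs from compound 3 in one place: isopropyl in place of phenyl on a saturated chain carbon bound to an aromatic carbon. All three measured steps exchange a group in the same outer region of the shared core, and none of them moved the number beyond the scatter. Going by the values given here, no measured step exchanges an aromatic ring for a saturated chain, so that part of the change has no direct precedent here; still, the variations seen so far leave the number unchanged.

On that basis compound 4 is expected to give 9.5, with a range from 9.2 to 9.8, which means an expected step of a number 0.03 log units higher from compound 3 to compound 4 (within the scatter) that stays within the scatter.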

Compound 4, acid dissociation constant: 9.47
Compound 4: the middle estimate sits 0.03 log units above what was measured, within the range that was stated.
By their numbers in this assay, from the lowest: compounds 1, 2, 3 and 4 (each within the scatter of the next).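

In this assay, going by these compounds alone, the exchange of phenyl for isopropyl on a saturated chain carbon bound to an aromatic carbon gives no change at the digits printed from compound 3 to compound 4 (within the scatter), the first measured step where a six-membered aromatic ring of carbon only leaves and a group with no ring enters. Measured against the two ether-linked groups, isobutyl gives a number 0.19 log units higher from compound 1 to compound 4 (within the scatter) in place of 4-fluorophenoxy and a number 0.19 log units higher from compound 2 to compound 4 (within the scatter) in place of 3-(dimethylamino)phenoxy. On this aromatic carbon, then, the outer ring and the linking oxygen can both be absent without any step beyond the scatter, which widens the range of groups over which the number holds, though only for these four compounds; nothing at hand offers an explanation for this.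

On these data alone, whether the same holds for a group carrying an amine or a carboxylic acid on this aromatic carbon, or for a longer chain there, remains open. As far as these compounds go, the rest of the shared core is the same in all four compounds, so the effect on the number of any exchange outside this one place also remains open.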